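Chloro at the position where methoxy had weakened binding

This account rests on a few compounds, and the source may have more. Where it says the series, first, only, none or still open, it means among the compounds named here.

Compound 3 `C1=C(c2cncc(Oc3ccccc3)c2)CC2CNCC1C2` is the anchor of this comparison. In an in vitro assay on SH-SY5Y cells for displacement of a labelled ligand from Neuronal acetylcholine receptor; alpha3/beta4 (Homo sapiens) (on this read-out higher numbers stand for weaker inhibition and lower numbers for stronger inhibition), compound 3 gives 1.9 nM, the lowest of the three numbers available. Compound 1 `C1=C(c2cncc(OCc3ccccc3)c2)CC2CNCC1C2` gives 44 nM and compound 2 `COc1ccccc1Oc1cncc(C2=CC3CNCC(C2)C3)c1` gives 56 nM; the gaps a 23-fold lower number from compound 1 to compound 3 (1.36 log units; beyond the scatter) and a 29-fold lower number from compound 2 to compound 3 (1.47 log units; beyond the scatter) are both beyond the scatter, so compound 3 stands clearly apart from the other two, while a 1.3-fold higher number from compound 1 to compound 2 (0.10 log units; within the scatter) keeps compounds 1 and 2 within the scatter of each other.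

Compound 4 `Clc1ccccc1Oc1cncc(C2=CC3CNCC(C2)C3)c1` differs from compound 3 by chloro in place of hydrogen on an aromatic carbon. The step that bears most directly on it is a 29-fold lower number from compound 2 to compound 3 (1.47 log units; beyond the scatter), in which removing the methoxy from this aromatic carbon, ortho to a large group, brought a large gain; going the other way, a substituent at that carbon cost a good deal. A chloro is a different group from methoxy, so the size of the penalty is uncertain, but some weakening is expected in this assay. Compound 4 is therefore estimated at 10 nM (range 3 nM to 40 nM), a step of a 5.3-fold higher number from compound 3 to compound 4 (0.72 log units; beyond the scatter).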

Compound 4, inhibition constant: 26 nM
Compound 4: middle estimate off by 2.6-fold (0.41 log units), on the low side; the range from low to high includes it.
By their numbers in this assay, from the lowest: compound 3; then compounds 4, 1 and 2 (each within the scatter of the next, the first and the last beyond it).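

In this assay, the step of a 14-fold higher number from compound 3 to compound 4 (1.14 log units; beyond the scatter) shows that the loss at this aromatic carbon, ortho to a large group, is not confined to methoxy: chloro, with its single heavy atom, also brings a large change. The identity of the group still counts, since a 2.2-fold lower number from compound 2 to compound 4 (0.33 log units; beyond the scatter) is a modest step beyond the scatter. By contrast, a 1.7-fold lower number from compound 1 to compound 4 (0.23 log units; within the scatter) lies within the scatter, so 2-chlorophenyl and benzyl on the oxygen cannot be told apart here. Nothing available gives a reason for these steps. The compounds shown leave open how fluoro or methyl would behave at this carbon, and whether the penalty falls between hydrogen and chloro. They also leave open whether chloro would have the same effect at the other carbons of this ring.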